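Replacing thiophen-2-yl with 2-bromophenyl in the series

The compounds below may be only part of what the source reports. "The series", "measured", "known", "first", "only" and "open" are said of these compounds alone.

In an assay (Equus caballus) for inhibition of Thromboxane-A synthase (Homo sapiens), using microsomes (on this read-out lower numbers stand for stronger inhibition and higher numbers for weaker inhibition), compound 3 `O=C(O)CCCC/C=C(\c1cccnc1)c1cccs1` gives 20 nM, the lowest of the three numbers recorded. Compound 2 `O=C(O)CCCC/C=C(/c1ccc(F)cc1)c1cccnc1` gives 83 nM in this assay, and compound 1 `O=C(O)CCCC/C=C(\c1cccnc1)c1cccc(Br)c1` gives 180 nM. Compound 4 `O=C(O)CCCC/C=C(\c1cccnc1)c1ccccc1Br` has not yet been measured. The change from compound 3 is 2-bromophenyl in place of thiophen-2-yl on a double-bonded chain carbon bound to an aromatic carbon and a double-bonded chain carbon, on the shared core.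

Going by the values given here, two measured steps bear on this change, each running the opposite way, from a substituted phenyl to thiophen-2-yl: a 9.0-fold lower number from compound 1 to compound 3 (0.95 log units; beyond the scatter) and a 4.2-fold lower number from compound 2 to compound 3 (0.62 log units; beyond the scatter). Among the compounds with values here, the step of a 2.2-fold lower number from compound 1 to compound 2 (0.34 log units; beyond the scatter) shows that the substituted phenyls are not interchangeable, and no measured compound carries 2-bromophenyl, so the size of the reversal is uncertain. The expectation is a higher number for compound 4, with a step of a 6.5-fold higher number from compound 3 to compound 4 (0.81 log units; beyond the scatter) judged from the two phenyl-to-thiophene steps. Compound 4 is therefore estimated at 130 nM in this assay, with a range from 35 nM to 500 nM.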

Compound 4, half-maximal inhibitory concentration: 130 nM
Compound 4: the middle estimate sits on the measured number at the digits printed; the measured number falls inside the stated range.
By their numbers in this assay, from the lowest: compound 3; then compounds 2, 4 and 1 (each within the scatter of the next, the first and the last beyond it).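

In this assay, the step of a 6.5-fold higher number from compound 3 to compound 4 (0.81 log units; beyond the scatter) is beyond the scatter, so thiophen-2-yl on this double-bonded chain carbon now stands apart from three substituted phenyls rather than two. The 2-bromophenyl group adds a further substitution pattern without separating itself from the others: a 1.4-fold lower number from compound 1 to compound 4 (0.14 log units; within the scatter) and a 1.6-fold higher number from compound 2 to compound 4 (0.19 log units; within the scatter) are both within the scatter. Compound 4 therefore cannot be ordered against either of these phenyl compounds, although the step of a 2.2-fold lower number from compound 1 to compound 2 (0.34 log units; beyond the scatter) remains beyond the scatter.

Open, as far as these compounds go, is whether the lower number is particular to thiophen-2-yl or is shared by furan-2-yl or an unsubstituted phenyl on this chain carbon. Nothing measured here accounts for the difference between thiophen-2-yl and the substituted phenyls.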